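This account rests on a few compounds, and the source may have more. Where it says the series, first, only, none or still open, it means among the compounds named here.

Compound 1 `O=C(COc1c(-c2ccccc2)oc2ccccc2c1=O)Nc1ccc2ccccc2c1` gives > 10000 nM (a limit)
Compound 2 `O=C(COc1ccc2c(=O)cc(-c3ccccc3)oc2c1)Nc1ccc2ccccc2c1` gives > 10000 nM (a limit)
Compound 3 `O=C(COc1c(-c2ccccc2)oc2ccccc2c1=O)Nc1ccc(F)cc1` gives > 10000 nM (a limit)

All three results come from a functional assay on MT2 cells (Homo sapiens) for antiproliferative activity, read by MTT assay, with a stated time of 72 h (a lower number here means a stronger inhibitor of growth, a higher number a weaker inhibitor of growth), and none of them is a true number. In this assay compound 3 gives > 10000 nM, which is a limit of the assay. The series as a whole shows (the limit of > 10000 nM in this assay, at which 3 of the 3 values shown sit), so compound 3 cannot be ranked against the others.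

Compound 4 `O=C(COc1c(-c2ccccc2)oc2ccccc2c1=O)Nc1ccc(-c2ccccc2)cc1` carries a single change from compound 3: phenyl in place of fluoro on an aromatic carbon. In words, this is phenyl in place of fluoro on an aromatic carbon, para to a large group.

Among the measured compounds shown here, the one measured step at this end of the molecule is a step that the two limits leave unreadable from compound 1 to compound 3, so it offers no size to carry over. For the measured compounds named here, with no measured step to lean on, no clear shift in either direction is expected, and another limit is the likeliest result. The expected step is a step that the limit leaves unreadable from compound 3 to compound 4, and it may prove just as unreadable. Compound 4 is estimated at 12000 nM, with an expected range from 4000 nM to 30000 nM.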

Compound 4, concentration for 50% growth inhibition: > 10000 nM
Compound 4: no number, only a limit; the forecaster's own chance of this, stated with the estimate: 85%; the middle value does not contradict the limit.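

Compound 4 gives > 10000 nM in this assay, which is a limit of the assay, so the change from compound 3 to compound 4 cannot be read as a step. The compounds shown leave open which changes, if any, would bring growth inhibition into a measurable range: the limit of > 10000 nM in this assay, at which 4 of the 4 values shown sit.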